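Para substituent swap: carboxy to butyl on the aryl hydrazone

The source may report more compounds than this note shows. Statements on the series, on what has been measured and on what is new or still open speak of the compounds shown alone.

Measured compounds:
compound 1 `CC1CC/C(=N\Nc2ccc(Br)cc2)c2ncc(C(=O)O)c(=O)n21` 0.8 umol/kg
compound 2 `Cc1ccc(N/N=C2\CCC(C)n3c2ncc(C(=O)O)c3=O)cc1` 1.3 umol/kg
compound 3 `CC1CC/C(=N\Nc2ccc(C(=O)O)cc2)c2ncc(C(=O)O)c(=O)n21` 7.6 umol/kg

In a functional assay on the whole organism for inhibition, with Rattus norvegicus as the target (on this read-out lower numbers stand for an effect already at smaller amounts and higher numbers for an effect only at larger amounts of compound), compound 3 gives 7.6 umol/kg, the highest of the three numbers; compounds 1 and 2 lie within the scatter of each other.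

Compound 4 `CCCCc1ccc(N/N=C2\CCC(C)n3c2ncc(C(=O)O)c3=O)cc1` differs from compound 3 by butyl in place of carboxy on an aromatic carbon.

Going by the values given here, two measured steps bear on this change, both running into compound 3: a 9.5-fold higher number from compound 1 to compound 3 (0.98 log units; beyond the scatter) and a 5.8-fold higher number from compound 2 to compound 3 (0.77 log units; beyond the scatter). Compound 4 removes the carboxy again and carries a hydrocarbon chain, so a step back toward the numbers of compounds 1 and 2 is expected, a modest drop beyond the scatter: a 5.1-fold lower number from compound 3 to compound 4 (0.70 log units; beyond the scatter). Compound 4 is therefore estimated at 1.5 umol/kg, in the range 0.6 umol/kg to 4 umol/kg.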

Compound 4, dose for 50% inhibition: 7.8 umol/kg
The estimate for compound 4 lay 5.2-fold (0.72 log units) below the measured number; measured number above the stated range.
By their numbers in this assay, from the lowest: compounds 1 and 2 (each within the scatter of the next); then compounds 3 and 4 (each within the scatter of the next).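

In this assay the swap gives (a 1.0-fold higher number from compound 3 to compound 4 (0.01 log units; within the scatter)), so at this place on the aromatic ring butyl and carboxy cannot be told apart, and the high number is not tied to carboxy alone. Nor does a hydrocarbon group as such keep the low numbers: butyl stands apart from methyl (a 6.0-fold higher number from compound 2 to compound 4 (0.78 log units; beyond the scatter)) and from bromo (a 9.8-fold higher number from compound 1 to compound 4 (0.99 log units; beyond the scatter)). Nothing measured here accounts for this shift.

Open, going by these compounds, is whether an ethyl or propyl chain at this place reads like methyl or like butyl. On these data alone, how an amine or a methoxy group reads here is also open.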